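Flipping one stereocentre of compound 2

The source may hold more compounds than are shown below. What is called first, only, known or untested is meant among the compounds shown, and "the series" means these compounds.

Compound 1 (`CC1=NN(c2ccccc2)C(=O)[C@@]12C(=O)C=CC[C@@H]2c1ccc(C)cc1`) gives 7420 nM
Compound 2 (`CC1=NN(c2ccccc2)C(=O)[C@@]12C(=O)C=CC[C@H]2c1cccc(C)c1`) gives 6610 nM

Both values come from a functional assay on MDA-MB-231 cells (Homo sapiens) for inhibition, read by MTT assay, with a stated time of 72 h (a higher number here means a weaker inhibitor, a lower number a stronger inhibitor), and sit within the usual scatter of each other, so compound 1 and compound 2 cannot be ranked. Compound 3 (`CC1=NN(c2ccccc2)C(=O)[C@@]12C(=O)C=CC[C@@H]2c1cccc(C)c1`) has the same atoms and bonds as compound 2 and differs only in configuration as drawn (the two compounds have the same atoms and bonds and differ only in configuration as drawn: 1 of 2 stereo elements differ; a stereocentre at a saturated ring carbon is drawn S in compound 2 and R in compound 3). Going by the values given here, no measured pair here shows what such a change does. In this assay no step beyond the scatter is expected, although the range stays wide. The estimated change is small (a 1.1-fold higher number from compound 2 to compound 3 (0.05 log units; within the scatter)). Compound 3 is expected at 7500 nM (range 3300 nM to 17000 nM).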

Compound 3, half-maximal inhibitory concentration: 6800 nM
Beside the measured number, compound 3's estimate is 1.1-fold (0.04 log units) above it; measured number inside the range.
By their numbers in this assay, from the lowest: compounds 2, 3 and 1 (each within the scatter of the next).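

In this assay, inverting this stereocentre on the saturated ring carbon has no effect beyond the scatter, with a 1.0-fold higher number from compound 2 to compound 3 (0.01 log units; within the scatter). With the configuration held the same, 3-methylphenyl in place of 4-methylphenyl also stays within the scatter, with a 1.1-fold lower number from compound 1 to compound 3 (0.04 log units; within the scatter). The first step can be read as that one stereocentre alone because nothing else varies: the fact that compounds 2 and 3 differ only in the configuration as drawn.

The compounds shown leave open what inverting the other stereocentre would do. They also leave open whether configuration would matter with an amine or a carboxylic acid on the phenyl ring in place of the methyl.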